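Adding a Second Chlorine to the Phenol Ring

A few compounds are considered here, and "the series" means these few. Any claim that something is new, unique, unknown or untested is made for them only; others in the source may bear on it.

Of the compounds shown here, three of one series have been tested in a functional assay on A549 cells (Homo sapiens) for inhibition, read by MTT assay, with a stated time of 48 h; on this read-out higher numbers stand for weaker inhibition and lower numbers for stronger inhibition. Compound 1 `C/C(=N\NC(=O)c1cc(-c2ccccc2)nn1Cc1ccc(C(C)(C)C)cc1)c1cc(C)ccc1O` gives 6100 nM in this assay. Compound 2 `C/C(=N\NC(=O)c1cc(-c2ccc(Cl)cc2)nn1Cc1ccc(C(C)(C)C)cc1)c1cc(C)ccc1O` carries chloro in place of hydrogen on an aromatic carbon, and in this assay compound 2 gives 2490 nM. That single change produced a 2.4-fold lower number from compound 1 to compound 2 (0.39 log units; beyond the scatter). Compound 3 `COc1ccc(-c2cc(C(=O)N/N=C(\C)c3cc(Cl)ccc3O)n(Cc3ccc(C(C)(C)C)cc3)n2)cc1` has a different core; the difference between the core of compound 1 and the core of compound 3 is not broken down here. In this assay compound 3 gives 9620 nM, the highest number of the three, though its gap to compound 1 falls within the scatter.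

Compound 4 `COc1ccc(-c2cc(C(=O)N/N=C(\C)c3cc(Cl)cc(Cl)c3O)n(Cc3ccc(C(C)(C)C)cc3)n2)cc1` has not yet been measured. It differs from compound 3 by chloro in place of hydrogen on an aromatic carbon. For the measured compounds named here, this is the same kind of change as the one from compound 1 to compound 2, but not the same: in compound 2 the new chloro sits para to a large group on a phenyl ring, whereas in compound 4 it sits ortho to a hydroxy group, meta to a chloro group and meta to a large group, on a ring that already carries a hydroxy group and a chloro group. Going by the values given here, the expected step in this assay is a 1.7-fold lower number from compound 3 to compound 4 (0.24 log units; within the scatter), a little smaller than the one earlier step. Among the compounds with values here, this expectation rests on a 2.4-fold lower number from compound 1 to compound 2 (0.39 log units; beyond the scatter), the only measured example of this kind of change, made in a different setting. The estimate for compound 4 in this assay is 5500 nM, with a range from 2500 nM to 12000 nM.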

Compound 4, half-maximal inhibitory concentration: 2080 nM
The estimate for compound 4 lay 2.6-fold (0.42 log units) above the measured number, and the stated range ends above it.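

Putting a chloro in place of hydrogen turns the 5-chloro-2-hydroxyphenyl group of compound 3 into the 3,5-dichloro-2-hydroxyphenyl group of compound 4, and in this assay this gives a 4.6-fold lower number from compound 3 to compound 4 (0.67 log units; beyond the scatter), which means stronger inhibition. For the compounds shown here, the change therefore lowered the number on both cores where it can be followed, and the two steps cannot be told apart in size: the same change on two cores in this assay, a 2.4-fold lower number (0.39 log units; beyond the scatter) from compound 1 to compound 2 and a 4.6-fold lower number (0.67 log units; beyond the scatter) from compound 3 to compound 4, 1.9-fold (0.28 log units) apart, within the scatter of two such steps This shows that the gain carried over from the core of compound 1 to the core of compound 3 in these two pairs, but it rests on only two steps in one assay, with the new chloro on a phenyl ring in compound 2 and on a ring that already carries a hydroxy group and a chloro group in compound 4, so it gives no general rule for chloro on this series and no reason why the number falls.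

The compounds shown leave open whether bromo, an amine or a carboxylic acid in the place of this new chloro would lower the number in the same way. They also leave open whether the same step would appear on further cores of the series, or on other cell types.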